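Chloro on the sulfonyl phenyl of a bis-fluorobenzylidene series

The source may hold more compounds than are shown below. What is called first, only, known or untested is meant among the compounds shown, and "the series" means these compounds.

Two members of the series have been measured in a functional assay on HepG2 cells (Homo sapiens) for cytotoxicity, read by MTT assay, with a stated time of 24 h; on this read-out higher numbers stand for weaker inhibition and lower numbers for stronger inhibition. Compound 1 `N#Cc1ccc(S(=O)(=O)N2C/C(=C\c3ccccc3F)C(=O)/C(=C/c3ccccc3F)C2)cc1` gives 16500 nM in this assay. Compound 2 `O=C1/C(=C/c2ccc(F)cc2)CN(S(=O)(=O)c2ccccc2)C/C1=C\c1ccc(F)cc1` gives 18800 nM in this assay. The two numbers lie within the usual scatter of each other, so compound 2 does not separate from compound 1 on the read-out; both sit in the same weak range. Among the measured compounds shown here, no pair of measured compounds differs in only one place, so no single step has yet been quantified.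

Compound 3 `O=C1/C(=C/c2ccc(F)cc2)CN(S(=O)(=O)c2ccc(Cl)cc2)C/C1=C\c1ccc(F)cc1` differs from compound 2 by chloro in place of hydrogen on an aromatic carbon. For the measured compounds named here, the measured pair offers no precedent for this change on the sulfonyl phenyl, so the expectation rests on the shared core alone. The step of a 1.1-fold lower number from compound 2 to compound 3 (0.04 log units; within the scatter) is expected to be none beyond the scatter. Compound 3 is estimated at 17000 nM in this assay, within 8000 nM to 36000 nM.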

Compound 3, half-maximal inhibitory concentration: 4500 nM
Estimate against measurement, compound 3: 3.8-fold (0.58 log units) above, outside the stated range (below it).
By their numbers in this assay, from the lowest: compound 3; then compounds 1 and 2 (each within the scatter of the next).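

Chloro in place of hydrogen on the sulfonyl phenyl is the first single change quantified in this series, and in this assay it gives a 4.2-fold lower number from compound 2 to compound 3 (0.62 log units; beyond the scatter). The step is modest, but it shows that the aromatic carbon para to a large group is a position where a single heavy atom can move the read-out beyond the scatter, which compounds 1 and 2 could not show. No measurement of any property of these compounds bears on the result, so the step stands without an explanation.

The compounds shown leave open whether another group on this carbon, such as methoxy, an amine or a carboxylic acid, would move the number as far, or the other way. As far as these compounds go, it also remains open whether chloro gives a similar step with the fluoro substituents placed as in compound 1.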